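Propoxy for propylsulfanyl on the shared core of compound 1

This account rests on a few compounds, and the source may have more. Where it says the series, first, only, none or still open, it means among the compounds named here.

The account follows a single change made on compound 1, whose structure is `CCCSc1nc(N)c2nc(O)n(Cc3ccccc3)c2n1`. In a functional assay (spleen, spleen) for activation, with Mus musculus as the target (a higher number here means that more compound is needed for the effect, a lower number that less compound is needed), compound 1 gives 0.01 uM, the only numerical value among the compounds shown. A second compound, compound 2 with the structure `CSc1nc2c(N)ncnc2n1Cc1ccccc1`, appears with > 10 uM in this assay, which is a limit of the assay and not a number; it is the point noted as the limit of > 10 uM in this assay, at which 1 of the 2 values shown sits. Within the data shown here, no step between two measured compounds differing in one place is available.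

Compound 3 has the structure `CCCOc1nc(N)c2nc(O)n(Cc3ccccc3)c2n1`. The change from compound 1 is propoxy in place of propylsulfanyl on an aromatic carbon. Among the measured compounds shown here, with no measured step to draw on, compound 3 is expected to stay close to compound 1, and the estimated step of a 2.0-fold higher number from compound 1 to compound 3 (0.30 log units; within the scatter) in this assay is expected to lie within the usual scatter. For compound 3 the estimate in this assay is 0.02 uM, between 0.003 uM and 0.1 uM.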

Compound 3, minimum effective concentration: 0.01 uM
Compound 3: middle estimate off by 2.0-fold (0.30 log units), on the high side; the range from low to high includes it.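

In this assay, among these compounds, the exchange of propylsulfanyl for propoxy gives no change at the digits printed from compound 1 to compound 3 (within the scatter), and this is the first step between two measured compounds that differ in one place. It shows that, on this aromatic carbon between two ring nitrogen atoms, the sulfur of the chain can give way to oxygen with the result staying within the scatter, so the read-out on the shared core does not depend on that one atom in this pair. Nothing shown gives a reason for this result.

The compounds shown leave open whether this position would accept groups of another kind, such as an amine, a carboxylic acid or a longer chain. A single step also cannot tell whether the same exchange would behave alike with a group other than benzyl on the core.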